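The source may hold more compounds than are shown below. What is called first, only, known or untested is meant among the compounds shown, and "the series" means these compounds.

Of the compounds shown here, three have been measured in an assay on isolated protein for inhibition of kynurenine 3-monooxygenase (Rattus norvegicus); on this read-out higher numbers stand for weaker inhibition and lower numbers for stronger inhibition. Compound 1, `Cc1ccc(S(=O)(=O)Nc2nc(-c3ccc(Cl)c(Cl)c3)cs2)cc1`, gives 56 nM. Compound 2, `O=C(O)CCC(=O)c1cccc([N+](=O)[O-])c1`, gives 5770 nM. Compound 3, `O=C(O)c1cc(-c2cccc([N+](=O)[O-])c2)on1`, gives 2680 nM. Among these three numbers compound 3 holds the second highest: compound 2 sits closest to it with a higher number, a gap beyond the scatter, while compound 1 lies far below it, a gap also well beyond the scatter.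

Compound 4, `O=[N+]([O-])c1cccc(-c2cc(-c3nn[nH]n3)no2)c1`, has not yet been measured in this assay. It differs from compound 3 in one place, (2H-tetrazol-5-yl in place of carboxy on an aromatic carbon), and nothing else in the structure changes.

Going by the values given here, no two measured compounds differ in a single place, so no measured step can be consulted for this change. Carboxy and 2H-tetrazol-5-yl each carry one hydrogen-bond donor, and the account rests on that likeness alone. The step from compound 3 to compound 4 is therefore expected to be small, within the scatter, with at most a slight lowering of the number, as a 1.3-fold lower number from compound 3 to compound 4 (0.13 log units; within the scatter). For compound 4 the expected value in this assay is 2000 nM, with a range from 600 nM to 6500 nM.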

Compound 4, half-maximal inhibitory concentration: 1160 nM
Estimate against measurement, compound 4: 1.7-fold (0.24 log units) above, within the range that was stated.
By their numbers in this assay, from the lowest: compound 1; then compound 4; then compound 3; then compound 2.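

Going by these compounds alone, the position on the five-membered aromatic ring with 1 nitrogen and 1 oxygen, next to the ring nitrogen, had no measured step before, and the exchange of carboxy for 2H-tetrazol-5-yl now gives one in this assay: a 2.3-fold lower number from compound 3 to compound 4 (0.36 log units; beyond the scatter), a modest change. It shows that carboxy is not needed at this place for the inhibition seen with compound 3, since a larger group with a five-membered aromatic ring with 4 hetero atoms takes its place and the number falls rather than rises. No measurement of any property accompanies this step, so it stands as an observation without an explanation.

Within the data shown here, still open is how a primary amide, a methyl ester or an amine would read at this same place, as carboxy and 2H-tetrazol-5-yl are the only two groups seen there. Also open, as far as these compounds go, is whether the step keeps its size when the group of 9 heavy atoms on the neighbouring ring atom changes, for example with an amine in place of its nitro group.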